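Carbonyl substituent variation: what to expect of compound 4

The source may report more compounds than this note shows. Statements on the series, on what has been measured and on what is new or still open speak of the compounds shown alone.

Among the compounds with values here, compound 3 `CC1=C(C(=O)CC(C)C)C(c2ccoc2)NC(=O)N1` gives 23% in an assay on membranes from CHO cells for displacement of a labelled ligand from adenosine receptor A1 (Homo sapiens), read by scintillation counting, with a stated time of 60 min, tested at 1 uM (a higher number here means more inhibition at the concentration tested (going by the name of the read-out), a lower number less inhibition), the highest of the three numbers measured so far; compound 1 `COC(=O)C1=C(C)NC(=O)NC1c1ccoc1` gives 8% and compound 2 `CCCC(=O)C1=C(C)NC(=O)NC1c1ccoc1` gives 1%. Both steps into compound 3 rise beyond the scatter, a number 15 percentage points higher from compound 1 to compound 3 (beyond the scatter) and a number 22 percentage points higher from compound 2 to compound 3 (beyond the scatter), while the step of a number 7 percentage points lower from compound 1 to compound 2 (within the scatter) stays within it. Compound 4 `CC1=C(C(=O)NC(C)C)C(c2ccoc2)NC(=O)N1` differs from compound 3 by isopropylamino in place of isobutyl on a carbonyl carbon. Within the data shown here, no measured step exchanges a carbon group for an amino group on the carbonyl carbon, so the two upward steps bear on compound 4 only in that the isobutyl of compound 3 leaves. For compound 4 a fall back toward the lower numbers is expected, a number 11 percentage points lower from compound 3 to compound 4 (beyond the scatter). Compound 4 is estimated at 12%, in the range 0% to 28%.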

Compound 4, a percentage reported as inhibition, at one concentration (the size of the read-out at that concentration, not a potency): 1%
Compound 4: middle estimate off by 11 percentage points, on the high side; low and high end bracket the measured number.
By their numbers in this assay, from the lowest: compounds 2, 4 and 1 (each within the scatter of the next); then compound 3.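

At the carbonyl carbon, isopropylamino in place of isobutyl removes the rise seen with compound 3 in this assay, with a number 22 percentage points lower from compound 3 to compound 4 (beyond the scatter) as the step, leaving compound 3 alone beyond the scatter of the other three. Against the other two carbonyl substituents, no change at the digits printed from compound 2 to compound 4 (within the scatter) and a number 7 percentage points lower from compound 1 to compound 4 (within the scatter) both stay within the scatter, so isopropylamino does not separate from propyl or methoxy. No evidence here accounts for the fall. Open, from the compounds shown here alone, is whether a longer chain or a cyclohexyl group on the carbonyl carbon would match or pass isobutyl, and whether an amino group carrying a longer chain would recover any of the rise.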